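Cytotoxicity at the aryl position of the diarylpyrimidine series

The source may report more compounds than this note shows. Statements on the series, on what has been measured and on what is new or still open speak of the compounds shown alone.

Compound 1 `Cc1cc(C#N)cc(C)c1Oc1nc(Nc2ccc(C#N)cc2)ncc1-c1cccs1`: 6430 nM
Compound 2 `Cc1cc(C#N)cc(C)c1Oc1nc(Nc2ccc(C#N)cc2)ncc1-c1ccncc1`: 28000 nM
Compound 3 `Cc1cc(C#N)cc(C)c1Oc1nc(Nc2ccc(C#N)cc2)ncc1-c1cncnc1`: > 298000 nM

In an ADME assay on MT4 cells (Homo sapiens) for cytotoxicity, read by MTT assay, with a stated time of 5 days (a higher number here means that more compound is tolerated, a lower number that less compound is tolerated), compound 1 gives the lowest of the two numbers shown, with compound 2 nearest at 28000 nM; the step is a 4.4-fold higher number from compound 1 to compound 2 (0.64 log units; beyond the scatter). For compound 3 the assay reports only a limit, > 298000 nM, as the evidence notes (the limit of > 298000 nM in this assay, at which 1 of the 3 values shown sits). Hence an at least 46-fold higher number from compound 1 to compound 3 (1.66 log units; beyond the scatter) and an at least 10-fold higher number from compound 2 to compound 3 (1.02 log units; beyond the scatter), both large; replacing thiophen-2-yl by ring systems with more nitrogen atoms raises the number in this assay across these three compounds.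

Compound 4 `Cc1cc(C#N)cc(C)c1Oc1nc(Nc2ccc(C#N)cc2)ncc1-c1ccc(F)cc1` is not yet measured. Its difference from compound 1 is 4-fluorophenyl in place of thiophen-2-yl on an aromatic carbon. The measured steps concern pyridin-4-yl and pyrimidin-5-yl, which both enter a nitrogen-bearing six-membered ring; 4-fluorophenyl brings no hetero atom into the ring, so those steps bear on it only by contrast. The number for compound 4 in this assay is therefore expected to stay close to that of compound 1, with a 1.2-fold lower number from compound 1 to compound 4 (0.07 log units; within the scatter) no larger than the scatter. Compound 4 is estimated at 5500 nM, with a range of 1800 nM to 18000 nM.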

Compound 4, half-maximal cytotoxic concentration: 42700 nM
The estimate for compound 4 lay 7.8-fold (0.89 log units) below the measured number; the whole stated range lies below it.
By their numbers in this assay, from the lowest: compound 1; then compounds 2 and 4 (each within the scatter of the next). At a limit, above all of these: compound 3.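

In this assay, a ring of carbon only also gives a higher number than thiophen-2-yl, with a 6.6-fold higher number from compound 1 to compound 4 (0.82 log units; beyond the scatter), so this rise at the position does not require a ring nitrogen. The step of a 1.5-fold higher number from compound 2 to compound 4 (0.18 log units; within the scatter) leaves 4-fluorophenyl and pyridin-4-yl unseparated, so the earlier link between more nitrogen atoms and a higher number does not hold between these two groups. Pyrimidin-5-yl still stands apart, with an at least 6.9-fold lower number from compound 3 to compound 4 (0.84 log units; beyond the scatter), and this step rests on a limit: the limit of > 298000 nM in this assay, at which 1 of the 4 values shown sits.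

On these data alone, it remains open whether the low number of compound 1 goes with the five-membered ring or with its sulfur, a question furan-2-yl could help to separate. Also open, as far as these compounds go, are the part played by the fluorine, which plain phenyl would test, and the reading of an amine or a carboxylic acid on that ring.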